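The compounds below may be only part of what the source reports. "The series", "measured", "known", "first", "only" and "open" are said of these compounds alone.

Measured so far:
- compound 1 `COc1cccc(/C=C/C(=O)/C=C/c2ccc(OCc3cn(CCCCCOc4cc(=O)oc5ccccc45)nn3)c(OC)c2)c1`: 34%
- compound 2 `COc1cccc(/C=C/C(=O)/C=C/c2ccc(OCc3cn(CCCOc4cc(=O)oc5ccccc45)nn3)c(OC)c2)c1`: 52%

In a functional assay on COLO 205 cells (Homo sapiens) for inhibition, read by sulforhodamine B assay, with a stated time of 48 h, tested at 50 uM (on this read-out higher numbers stand for more inhibition of growth at the one concentration tested and lower numbers for less inhibition of growth), compound 2 gives 52%, the higher of the two values in hand. Compound 1 lies lower by more than the scatter. With only these two measurements, no trend in the series can be claimed.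

Next in line is compound 3 `COc1cc(/C=C/C(=O)/C=C/c2cc(OC)c(OC)c(OC)c2)ccc1OCc1cn(CCCOc2cc(=O)oc3ccccc23)nn1`, which departs from compound 2 at a single place: 3,4,5-trimethoxyphenyl in place of 3-methoxyphenyl on a double-bonded chain carbon bound to a double-bonded chain carbon. In words, 3,4,5-trimethoxyphenyl stands in place of 3-methoxyphenyl on a double-bonded chain carbon bound to a double-bonded chain carbon.

For the measured compounds named here, no measured pair shows this change or any other single-place change, so neither its size nor its direction has precedent here. The working expectation is therefore a small rise at most, with no shift beyond the scatter in this assay. The expected step of a number 3 percentage points higher from compound 2 to compound 3 (within the scatter) is slight and upward. The range stays wide, as the data offer no direct guide. For compound 3 the estimated value is 55%, with an expected range of 37% to 73%.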

Compound 3, percent growth inhibition at one concentration: 74%
Compound 3: middle estimate off by 19 percentage points, on the low side; the measured number lies above the stated range.
By their numbers in this assay, from the lowest: compound 1; then compound 2; then compound 3.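

In this assay, for the compounds shown here, this is the first pair that differs in one place, and it gives this position both a direction and a size: 3,4,5-trimethoxyphenyl in place of 3-methoxyphenyl, on a double-bonded chain carbon bound to a double-bonded chain carbon, gives a number 22 percentage points higher from compound 2 to compound 3 (beyond the scatter). Growth inhibition at the one concentration tested therefore responds to the group held at this place, even though the ring type stays the same, with 12 heavy atoms and 3 hydrogen-bond acceptors entering against 8 and 1 leaving. Nothing available links the step to any particular feature of the entering group.

A single pair cannot show whether the step follows from the number of methoxy groups or from the particular 3,4,5-trimethoxyphenyl arrangement, and a plain phenyl ring, a pyridine ring or an aryl group bearing an amine would test how far this position tolerates other groups. Also open, on these data alone, is whether the same exchange gives a similar step on the core of compound 1, whose chain is longer than that of compound 2.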